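The compounds below may be only part of what the source reports. "The series", "measured", "known", "first", "only" and "open" are said of these compounds alone.

Of the compounds shown here, three built on one shared core have been measured in a functional assay on Hep 3B2 cells (Homo sapiens) for antiproliferative activity, read by MTT assay, with a stated time of 24 h, tested at 0.14 ug/mL; on this read-out lower numbers stand for a weaker effect and higher numbers for a stronger effect at the one concentration tested. Compound 1 `CCc1ccc2nc(C(=O)Nc3c(F)cc(-c4cccc(F)c4)cc3F)c(C)c(O)c2c1` gives 11.2%. Compound 2 `Cc1c(C(=O)Nc2c(F)cc(-c3cccc(F)c3)cc2F)nc2ccc(F)cc2c1O` gives 2.65%, which stands between the other two numbers, though all three lie within the scatter of one another. Compound 3 `Cc1c(C(=O)Nc2c(F)cc(-c3cccc(F)c3)cc2F)nc2ccc(OC(F)(F)F)cc2c1O` gives 2.01%. The steps of a number 8.6 percentage points lower from compound 1 to compound 2 (within the scatter) and a number 9.2 percentage points lower from compound 1 to compound 3 (within the scatter) are small, and so is a number 0.6 percentage points lower from compound 2 to compound 3 (within the scatter).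

Compound 4 `Cc1c(C(=O)Nc2c(F)cc(-c3cccc(F)c3)cc2F)nc2ccc(C(F)(F)F)cc2c1O` differs from compound 2 in one place: trifluoromethyl in place of fluoro on an aromatic carbon. The closest guide is the exchange of fluoro for trifluoromethoxy, where a number 0.6 percentage points lower from compound 2 to compound 3 (within the scatter) stayed within the scatter, as did every other step seen here. No step beyond the scatter is therefore expected in this assay.

Compound 4 is estimated at 3%, with a range from 0% to 12%. The expected step is a number 0.4 percentage points higher from compound 2 to compound 4 (within the scatter).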

Compound 4, a percentage reported as inhibition, at one concentration (the size of the read-out at that concentration, not a potency): 2.65%
For compound 4 the middle estimate is 0.4 percentage points above the measured one; measured number inside the range.
By their numbers in this assay, from the lowest: compounds 3, 2, 4 and 1 (each within the scatter of the next).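

In this assay this aromatic carbon also takes trifluoromethyl, with 4 heavy atoms in place of the 1 of fluoro, and the result is no change at the digits printed from compound 2 to compound 4 (within the scatter) (the size of the exchange changes nothing that can be read). The other two exchanges ending in compound 4 also stay inside the scatter (a number 0.6 percentage points higher from compound 3 to compound 4 (within the scatter); a number 8.6 percentage points lower from compound 1 to compound 4 (within the scatter)). Across ethyl, fluoro, trifluoromethoxy and trifluoromethyl, no exchange at this carbon has moved the number beyond the scatter.

From the compounds shown here alone, whether an amine, a carboxylic acid or a longer chain here would do so stays open. Nothing at hand gives a reason for these numbers.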